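Swapping the Ring on the Thiocarbonyl Carbon

The source may hold more compounds than are shown below. What is called first, only, known or untested is meant among the compounds shown, and "the series" means these compounds.

Measured so far in a functional assay on A-375 cells (Homo sapiens) for cytotoxicity, read by MTT assay, with a stated time of 72 h; a lower number here means a stronger inhibitor, a higher number a weaker inhibitor:
compound 1 `Cc1ccnc(/C(N)=N/NC(=S)N2CCSCC2)c1` gives 1200 nM;
compound 2 `N/C(=N\NC(=S)N1CCSCC1)c1ccccn1` gives 760 nM;
compound 3 `N/C(=N\NC(=S)N1CCN(c2ccccn2)CC1)c1ccccn1` gives 700 nM.

Compound 2 stands second highest of these three numbers, and its gaps to compound 1 and to compound 3 are both within the scatter. Compound 4 `N/C(=N\NC(=S)N1CCCC1)c1ccccn1` differs from compound 2 by one change: pyrrolidin-1-yl in place of thiomorpholin-4-yl on a thiocarbonyl carbon. Going by the values given here, the only measured step, a 1.6-fold lower number from compound 1 to compound 2 (0.20 log units; within the scatter), concerns a different place and does not bear on this ring swap. Compound 3 also carries a different ring at the same place, and its number sits close to that of compound 2, which suggests the ring there matters little. No step beyond the scatter is therefore expected; the estimated step is a 1.1-fold higher number from compound 2 to compound 4 (0.02 log units; within the scatter). Compound 4 is expected to give 800 nM, in the range 350 nM to 1800 nM.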

Compound 4, half-maximal inhibitory concentration: 600 nM
For compound 4 the middle estimate is 1.3-fold (0.12 log units) above the measured one; the range from low to high includes it.
By their numbers in this assay, from the lowest: compounds 4, 3, 2 and 1 (each within the scatter of the next).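

Going by these compounds alone, the step to pyrrolidin-1-yl (a 1.3-fold lower number from compound 2 to compound 4 (0.10 log units; within the scatter)) is the first direct reading at this position. On a thiocarbonyl carbon, the five-membered ring without sulfur can stand in place of thiomorpholin-4-yl with no change beyond the scatter. Nothing measured here explains this result through a property of either ring.

Still open, going by these compounds, is whether an open-chain group such as dimethylamino, or a ring bearing a carboxylic acid, would also stay within the scatter at this place. On these data alone, it is also open whether this swap behaves the same alongside the methyl of compound 1.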